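This account rests on a few compounds, and the source may have more. Where it says the series, first, only, none or still open, it means among the compounds named here.

Of the compounds shown here, three that share one core have been tested in a functional assay on the whole organism for inhibition, with Artemia salina as the target; on this read-out lower numbers stand for stronger inhibition of growth and higher numbers for weaker inhibition of growth. Compound 1 `CO[C@H]1C[C@H](O[Si](C)(C)C(C)(C)C)O[C@@H](C)/C1=C\C=N\O` gives 0.002 ug/mL in this assay. Compound 2 `CO[C@H]1C[C@H](O[Si](C)(C)C(C)(C)C)O[C@@H](C)/C1=C/CO` gives 0.01 ug/mL in this assay, and compound 3 `CO[C@H]1C[C@H](O[Si](C)(C)C(C)(C)C)O[C@@H](C)/C1=C\COC(=O)c1ccncc1` gives 0.01 ug/mL in this assay. Compound 2 thus stands level with compound 3 at the digits shown, the two of them together giving the highest numbers of the three, while compound 1 lies clearly lower, a gap beyond the scatter.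

Compound 4 `C=CCOC(=O)/C=C1/[C@H](C)O[C@@H](O[Si](C)(C)C(C)(C)C)C[C@@H]1OC` has not yet been measured. It differs from compound 2 by allyloxycarbonyl in place of hydroxymethyl on a double-bonded chain carbon bound to a double-bonded ring carbon. Among the measured compounds shown here, no step between two measured compounds matches this change, so there is no directly comparable result to lean on. For the measured compounds named here, the only guide is that compound 3, which also carries an ester in place of the alcohol of compound 2, sits level with compound 2 in this assay. The step expected for compound 4, no change at the digits printed from compound 2 to compound 4 (within the scatter), is therefore none beyond the scatter. For compound 4 the estimated value in this assay is 0.01 ug/mL, with a range from 0.003 ug/mL to 0.04 ug/mL.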

Compound 4, minimum inhibitory concentration: 0.002 ug/mL
Compound 4: middle estimate off by 2.3 two-fold dilutions, on the high side; the whole stated range lies above it.
By their numbers in this assay, from the lowest: compounds 1 and 4 (each within the scatter of the next); then compounds 2 and 3 (each within the scatter of the next).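

In this assay, allyloxycarbonyl in place of hydroxymethyl on a double-bonded chain carbon bound to a double-bonded ring carbon gives a number 2.3 two-fold dilutions lower from compound 2 to compound 4 (beyond the scatter). Among the compounds shown here, compound 3, also an ester, stands level with compound 2, so the earlier compounds gave no sign that this end of the chain could shift the number, whereas compound 4 now sits within the scatter of compound 1. Nothing measured here explains the shift.

The compounds shown leave open whether the shift comes from the carbonyl on the chain carbon or from the allyl part of the ester. A carboxylic acid, a methyl ester or an amide on that same chain carbon would help to separate these two readings.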